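The source may hold more compounds than are shown below. What is called first, only, known or untested is meant among the compounds shown, and "the series" means these compounds.

Measured so far in an ADME assay on Caco-2 cells (Homo sapiens) for permeability, in the apical to basolateral direction, with a stated time of 2 h, tested at 10 uM; on this read-out lower numbers stand for lower permeability and higher numbers for higher permeability:
- compound 1 `Cc1cc(C2CCCCCC2)n(O)c(=O)c1`: 5.74 10^-6 cm/s
- compound 2 `O=c1cc(-c2ccccc2)cc(CC2CCCCC2)n1O`: 2.75 10^-6 cm/s

Of these two compounds, compound 2 has the lower number at 2.75 10^-6 cm/s, and the gap to compound 1 at 5.74 10^-6 cm/s lies just beyond the usual scatter. The two differ in more than one place, so this gap cannot be tied to any single structural change.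

Compound 3 `O=c1cc(-c2ccccc2)cc(C2CCCCC2)n1O` is not yet measured. Relative to compound 2, it has cyclohexyl in place of cyclohexylmethyl on an aromatic carbon, and the rest of the structure is unchanged.

Within the data shown here, the series holds no measured pair that differs in one place, so the size of this step has no direct precedent. The estimate therefore starts from compound 2 at 2.75 10^-6 cm/s, the nearest measured structure. In this assay, a small upward move that stays within the scatter is expected, estimated as a 1.2-fold higher number from compound 2 to compound 3 (0.09 log units; within the scatter). For compound 3 the expected value is 3.4 10^-6 cm/s, with an estimated range of 1.7 10^-6 cm/s to 6.8 10^-6 cm/s.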

Compound 3, apparent permeability: 4.33 10^-6 cm/s
Compound 3: the middle estimate sits 1.3-fold (0.11 log units) below what was measured, and the stated range covers the measured number.
By their numbers in this assay, from the lowest: compounds 2, 3 and 1 (each within the scatter of the next, the first and the last beyond it).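

In this assay, among these compounds, cyclohexyl in place of cyclohexylmethyl on an aromatic carbon, next to the ring nitrogen, gives a 1.6-fold higher number from compound 2 to compound 3 (0.20 log units; within the scatter), and this is the first step that can be read at a single place. At this position, with the phenyl group and the rest of the structure unchanged, the read-out therefore does not separate cyclohexyl, with 6 heavy atoms, from cyclohexylmethyl, with 7 heavy atoms, so this change shows no effect that stands clear of the scatter. No supporting data bear on the origin of this small step.

Open, from the compounds shown here alone, is whether a longer chain such as cyclohexylethyl, or a group carrying an amine or a carboxylic acid on this same aromatic carbon, would stay within the scatter of compound 2 or move beyond it. Compound 1 differs from compound 2 and from compound 3 in more than one place, so the separate contributions of its cycloheptyl and methyl groups cannot be read from these compounds.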